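Stretching methyl to propyl on compound 1

The compounds below may be only part of what the source reports. "The series", "measured", "known", "first", "only" and "open" are said of these compounds alone.

Compound 1 `C/C(=N\Nc1nc2ccccc2o1)c1ccccn1` gives the lowest number of the three measured compounds in a functional assay on CCRF-CEM cells (Homo sapiens) for antiproliferative activity, read by MTT assay (on this read-out lower numbers stand for stronger inhibition and higher numbers for weaker inhibition), at 15 nM. Two relatives replace its pyridin-2-yl group: compound 2 `C/C(=N\Nc1nc2ccccc2o1)c1ncccn1` reads 130 nM, and compound 3 `C/C(=N\Nc1nc2ccccc2o1)c1ccc2ccccc2n1` reads 7040 nM. Compound 4 `CCC/C(=N\Nc1nc2ccccc2o1)c1ccccn1` keeps the pyridin-2-yl group and changes the chain instead, turning methyl to propyl: ethyl in place of hydrogen on a saturated chain carbon bound to a carbon with a double bond to nitrogen. This puts ethyl in place of hydrogen on a saturated chain carbon bound to a carbon with a double bond to nitrogen.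

Going by the values given here, no measured step touches this chain, so the evidence is indirect. The nearest guide is the swap to pyrimidin-2-yl, which gave an 8.7-fold higher number from compound 1 to compound 2 (0.94 log units; beyond the scatter) at a different place in the molecule. Compound 1 also already sits at the low end of the numbers, so a modest rise in this assay seems more likely than a further fall. The expected change is a 4.0-fold higher number from compound 1 to compound 4 (0.60 log units; beyond the scatter), towards weaker inhibition. For compound 4 the estimate is 60 nM, with an expected range from 10 nM to 400 nM.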

Compound 4, half-maximal inhibitory concentration: 6 nM
The estimate for compound 4 lay 10-fold (1.00 log units) above the measured number, outside the stated range (below it).
By their numbers in this assay, from the lowest: compound 4; then compound 1; then compound 2; then compound 3.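

Going by these compounds alone, this is the first measured change at the chain, and in this assay stretching methyl to propyl gives a 2.5-fold lower number from compound 1 to compound 4 (0.40 log units; beyond the scatter), so this position takes the added ethyl with a modest gain rather than a loss. The earlier compounds shown here varied only the pyridin-2-yl group, and both of those replacements raised the number, so they could not show that the chain offers a further way to lower it. Nothing measured here explains why the longer chain lowers the number.

From the compounds shown here alone, whether the number keeps falling with a longer chain such as butyl or pentyl, or how a branched isopropyl group or a terminal amine would read, remains open. Going by these compounds, it is also open whether propyl would bring a similar gain on the pyrimidin-2-yl group of compound 2.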